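The source may report more compounds than this note shows. Statements on the series, on what has been measured and on what is new or still open speak of the compounds shown alone.

Working notes on the series. In a functional assay on OVCAR-3 cells (Homo sapiens) for antiproliferative activity, read by MTT assay, with a stated time of 24 h (a higher number here means a weaker inhibitor, a lower number a stronger inhibitor), compound 2 `Cc1ccc(-n2cc(-c3cccc(NS(=O)(=O)c4c[nH]c(=O)[nH]c4=O)c3)nn2)cc1` gives 3540 nM, and compound 1 `Cc1cccc(-n2cc(-c3cccc(NS(=O)(=O)c4c[nH]c(=O)[nH]c4=O)c3)nn2)c1` gives 4080 nM; the two sit within the scatter of each other, as a 1.2-fold lower number from compound 1 to compound 2 (0.06 log units; within the scatter) shows. Compound 3 `O=c1[nH]cc(S(=O)(=O)Nc2cccc(-c3cn(-c4ccccc4Cl)nn3)c2)c(=O)[nH]1` carries 2-chlorophenyl in place of 4-methylphenyl on an aromatic nitrogen. For the measured compounds named here, no measured step exchanges a methyl group for a chlorine; the single step known, from compound 1 to compound 2, moves a methyl group and stays within the scatter, so no clear direction is indicated. Compound 3 is therefore expected to show a 1.0-fold lower number from compound 2 to compound 3 (0.00 log units; within the scatter), with an estimated 3500 nM in this assay, between 1500 nM and 8000 nM.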

Compound 3, half-maximal inhibitory concentration: 5370 nM
Estimate against measurement, compound 3: 1.5-fold (0.19 log units) below, and the stated range covers the measured number.
By their numbers in this assay, from the lowest: compounds 2, 1 and 3 (each within the scatter of the next).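

In this assay, the 2-chlorophenyl group on the aromatic nitrogen stands within the scatter of both methylphenyl groups (a 1.5-fold higher number from compound 2 to compound 3 (0.18 log units; within the scatter)) and (a 1.3-fold higher number from compound 1 to compound 3 (0.12 log units; within the scatter)). This position therefore accepts a chlorine in place of a methyl group, on a different ring position, with no step beyond the scatter, and the three compounds show no clear preference among these groups. No evidence is available that bears on these steps. On these data alone, whether an amine, a carboxylic acid or a longer chain on this ring would give a step beyond the scatter remains open. Also open, as far as these compounds go, is how chlorine compares with methyl at one and the same ring position.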